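The compounds below may be only part of what the source reports. "The series", "measured", "known", "first", "only" and "open" are said of these compounds alone.

Of the compounds shown here, three built on a shared core have been measured in a functional assay on HEK293 cells for agonist activity at Neuronal acetylcholine receptor; alpha4/beta2 (Homo sapiens), read by FLIPR and calcium flux; on this read-out higher numbers stand for an effect only at larger amounts of compound and lower numbers for an effect already at smaller amounts. Compound 1 `COc1cc(N2CCCNCC2)cnc1Cl` gives 91.2 nM. Compound 3 `Oc1cc(N2CCCNCC2)cnc1I` gives 479 nM. Compound 2 `C=COc1cncc(N2CCNCC2)c1` gives 7590 nM, the highest of the three numbers; its gaps to compound 3 and to compound 1 both lie beyond the usual scatter, so compound 2 is the one that needs the largest amount of substance for an effect in this assay.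

Compound 4 `Clc1cncc(N2CCNCC2)c1` has not yet been measured. It differs from compound 2 in a single place: chloro in place of vinyloxy on an aromatic carbon. Among the compounds with values here, no pair of measured compounds differs by exactly this change, so there is no measured step to set beside it. Even so, compound 1, which also carries a chloro group on its core, gives 91.2 nM, far under the number of compound 2, and this points downward. The step expected here is a 3.0-fold lower number from compound 2 to compound 4 (0.48 log units; beyond the scatter), beyond the scatter. For compound 4 the estimated value is 2500 nM, with a range from 600 nM to 10000 nM.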

Compound 4, half-maximal effective concentration: 22900 nM
Compound 4: middle estimate off by 9.2-fold (0.96 log units), on the low side; measured number outside the range, above it.
By their numbers in this assay, from the lowest: compound 1; then compound 3; then compound 2; then compound 4.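

On an aromatic carbon two atoms from the ring nitrogen, chloro in place of vinyloxy gives a 3.0-fold higher number from compound 2 to compound 4 (0.48 log units; beyond the scatter) in this assay, so this change moves the number up, not down. Within the data shown here, this is the first direct comparison of two groups at this position, and of the pair, vinyloxy is the one that gives an effect at smaller amounts of compound, so a chloro group does not bring a low number by itself on this core. No measurement shown here explains the rise.

From the compounds shown here alone, only these two groups can be compared at this carbon, so it remains open how an amino group, a nitrile or a longer chain such as propoxy would behave there. Going by these compounds, whether the same change would act alike on compound 1 or compound 3 also stays open.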